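Notes on compound 4 against compound 1

The source may hold more compounds than are shown below. What is called first, only, known or untested is meant among the compounds shown, and "the series" means these compounds.

Compound 1 `COc1cc(O)c(C=O)c2c1[C@H](O)C[C@@H](c1ccccc1)O2` is the point of departure. In a functional assay on HepG2 cells (Homo sapiens) for cytotoxicity, read by MTT assay (on this read-out higher numbers stand for weaker inhibition and lower numbers for stronger inhibition), compound 1 is recorded as "not active" (no number reported), an entry without a number, so compound 1 holds no place on a numerical scale here. Compound 3 `COc1cc(O)c(C=O)c2c1[C@H](OC)C[C@@H](c1ccccc1)O2` likewise returns "not active" (no number reported) in this assay. Among the compounds with values here, the single numbered result belongs to compound 2 `COc1c(C)c(OC)c2c(c1C)O[C@H](c1ccccc1)C[C@H]2O`, which in this assay gives 135000 nM; no step from compound 1 or compound 3 to compound 2 can be stated from entries without a number. Compound 4 `COc1c(C)c(O)c(C=O)c2c1[C@H](O)C[C@@H](c1ccccc1)O2` is still to be measured. It differs from compound 1 by methyl in place of hydrogen on an aromatic carbon. Within the data shown here, no measured pair covers this change. In this assay the expectation is a step of no size beyond the usual scatter, with compound 4 most likely returned without a number, as compound 1 and compound 3 were. Should a number be reported, the estimate for compound 4 in this assay is 200000 nM, expected to lie within a range from 70000 nM to 600000 nM.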

Compound 4, half-maximal inhibitory concentration: 143000 nM
Compound 4: the middle estimate sits 1.4-fold (0.15 log units) above what was measured; the measured number falls inside the stated range.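

Within the data shown here, compound 4 now carries a number, but compound 1 has none, so no step from compound 1 to compound 4 can be read. The compounds shown leave open what methyl in place of hydrogen does in this assay. Nothing available bears on the result.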